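Lengthening the aryloxy acid chain in a peroxide series

The compounds below may be only part of what the source reports. "The series", "measured", "known", "first", "only" and "open" are said of these compounds alone.

compound 1 `O=C(O)CNC(=O)COc1ccc([C@H]2CC[C@]3(CC2)OOC2(O3)C3CC4CC(C3)CC2C4)cc1`: 3
compound 2 `O=C(O)COc1ccc([C@H]2CC[C@]3(CC2)OOC2(O3)C3CC4CC(C3)CC2C4)cc1`: 2.9

Compound 1 and compound 2 share one core and differ only at the carbonyl carbon. In a physicochemical assay for lipophilicity, read by HPLC, at pH 7.4 (a higher number here means a more lipophilic compound, a lower number a more polar compound), compound 1 gives 3 and compound 2 gives 2.9; compound 2 holds the smaller of the two numbers, yet the step of a number 0.10 log units lower from compound 1 to compound 2 (within the scatter) sits within the scatter. Compound 3 `O=C(O)CCCOc1ccc([C@H]2CC[C@]3(CC2)OOC2(O3)C3CC4CC(C3)CC2C4)cc1` differs from compound 2 in one place: 2-carboxyethyl in place of carboxy on a saturated chain carbon bound to an oxygen on an aromatic ring. Among the compounds with values here, no measured step adds chain carbons, so the step of a number 0.10 log units lower from compound 1 to compound 2 (within the scatter) offers no direct guide. Compound 3 is nonetheless expected to read higher in this assay, by a number 0.80 log units higher from compound 2 to compound 3 (beyond the scatter), giving an estimate of 3.7 with a range from 3.2 to 4.3.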

Compound 3, distribution coefficient: 3.6
Compound 3: middle estimate off by 0.10 log units, on the high side; low and high end bracket the measured number.
By their numbers in this assay, from the lowest: compounds 2 and 1 (each within the scatter of the next); then compound 3.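

In this assay, within the data shown here, this position now responds to a change: 2-carboxyethyl in place of carboxy gives a number 0.70 log units higher from compound 2 to compound 3 (beyond the scatter), the first step here beyond the scatter. The same group in place of (carboxymethyl)carbamoyl gives a number 0.60 log units higher from compound 1 to compound 3 (beyond the scatter), so compound 3 stands apart from both compound 1 and compound 2, which lie within the scatter of each other. Nothing at hand explains this step. The compounds shown leave open whether a longer chain ending in a carboxylic acid would read higher still, and how an amine at the chain end would read.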